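Chlorophenyl in place of thiophene at the carbonyl

The compounds below may be only part of what the source reports. "The series", "measured", "known", "first", "only" and "open" are said of these compounds alone.

Three compounds share one core and differ only in the group attached to a carbonyl carbon. Compound 1 `COc1cc(-c2nnc3n2NC(c2ccco2)C(C(=O)c2ccccc2C)S3)cc(OC)c1OC` carries 2-methylphenyl there, and in a functional assay on HepG2 cells (Homo sapiens) for cytotoxicity, read by MTT assay, with a stated time of 48 h (a higher number here means a weaker inhibitor, a lower number a stronger inhibitor), compound 1 gives 63000 nM. Compound 3 `COc1cc(-c2nnc3n2NC(c2ccco2)C(C(=O)c2cccs2)S3)cc(OC)c1OC` carries thiophen-2-yl instead; in this assay compound 3 gives 64100 nM, the highest of the two numbers reported, although the step of a 1.0-fold higher number from compound 1 to compound 3 (0.01 log units; within the scatter) stays within the scatter. Compound 2 `COc1cc(-c2nnc3n2NC(c2ccco2)C(C(=O)c2ccc(Br)cc2)S3)cc(OC)c1OC` carries 4-bromophenyl. In this assay compound 2 gives > 100000 nM, which is a limit of the assay and not a number, namely (the limit of > 100000 nM in this assay, at which 1 of the 3 values shown sits).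

Compound 4 `COc1cc(-c2nnc3n2NC(c2ccco2)C(C(=O)c2ccc(Cl)cc2)S3)cc(OC)c1OC` has not been measured. Its difference from compound 3 is 4-chlorophenyl in place of thiophen-2-yl on a carbonyl carbon. Among the measured compounds shown here, two measured steps bear on this change, both involving a 4-halophenyl at the same carbonyl carbon: an at least 1.5-fold higher number from compound 1 to compound 2 (0.20 log units; that floor lies within the scatter) and an at least 1.5-fold lower number from compound 2 to compound 3 (0.19 log units; that floor lies within the scatter). Both point toward a higher number, and therefore weaker cytotoxicity, when a 4-halophenyl occupies that place, though each step reaches only a floor that lies within the scatter. The expected step is therefore a 1.5-fold higher number from compound 3 to compound 4 (0.17 log units; within the scatter), upward, with a real chance that only a limit is reported again. Compound 4 is estimated at 95000 nM, within a range from 50000 nM to 200000 nM.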

Compound 4, half-maximal inhibitory concentration: 78600 nM
The estimate for compound 4 lay 1.2-fold (0.08 log units) above the measured number; low and high end bracket the measured number.
By their numbers in this assay, from the lowest: compounds 1, 3 and 4 (each within the scatter of the next). At a limit, above all of these: compound 2.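

At this carbonyl carbon, the new number shows that a 4-halophenyl group need not end at the limit of this assay: 4-chlorophenyl in place of thiophen-2-yl is a 1.2-fold higher number from compound 3 to compound 4 (0.09 log units; within the scatter), and 4-chlorophenyl in place of 2-methylphenyl is a 1.2-fold higher number from compound 1 to compound 4 (0.10 log units; within the scatter), so these three groups cannot be told apart here. Chloro in place of bromo on an aromatic carbon reads an at least 1.2-fold lower number from compound 2 to compound 4 (0.10 log units; that floor lies within the scatter), which is only a floor, so how far apart the two halogens lie remains unknown. Compound 2 still has a limit of the assay and not a number: the limit of > 100000 nM in this assay, at which 1 of the 4 values shown sits.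

All the groups shown at this carbonyl carbon are aromatic rings, leaving open whether an amine, a carboxylic acid or a longer chain there would shift the number beyond the scatter. The rest of the shared core stays the same throughout, so these compounds also leave open whether a change elsewhere, such as another ring in place of the furan, would matter more than any change at this carbonyl carbon.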